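Cytotoxicity series notes: from compound 2 to compound 3

A few compounds are considered here, and "the series" means these few. Any claim that something is new, unique, unknown or untested is made for them only; others in the source may bear on it.

Measured in a functional assay on A-427 cells (Homo sapiens) for cytotoxicity, read by colorimetric assay and MTT assay; a lower number here means a stronger inhibitor, a higher number a weaker inhibitor:
- compound 1 `COc1cccc2cc(-c3ccccc3)c(O)nc12` at 10000 nM
- compound 2 `COc1ccc(-c2cc3c(OC)cc(OC)cc3n(CC#N)c2=O)cc1` at 10000 nM

Compound 2 stands level with compound 1, and the two values lie within the scatter of each other. Among the compounds with values here, no measured step between closely matched compounds is available to guide the next one.

Compound 3 `CCN(CC)C(=O)CCn1c(=O)c(-c2ccc(OC)cc2)cc2c(OC)cc(OC)cc21` differs from compound 2 as follows: (diethylcarbamoyl)methyl in place of cyano on a saturated chain carbon bound to an aromatic nitrogen (on a saturated chain carbon bound to an aromatic nitrogen).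

In this assay no step beyond the scatter is expected, and neither direction is favoured, with an estimated 1.3-fold lower number from compound 2 to compound 3 (0.10 log units; within the scatter) as the working figure. The only anchors for this expectation are compound 1 at 10000 nM and compound 2 at 10000 nM in the same assay. The estimate for compound 3 is 8000 nM within an expected range from 3000 nM to 20000 nM for now.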

Compound 3, half-maximal inhibitory concentration: 10000 nM
For compound 3 the middle estimate is 1.3-fold (0.10 log units) below the measured one; low and high end bracket the measured number.
By their numbers in this assay, from the lowest: compounds 1, 2 and 3 (each within the scatter of the next).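

In this assay, (diethylcarbamoyl)methyl in place of cyano on a saturated chain carbon bound to an aromatic nitrogen gives no change at the digits printed from compound 2 to compound 3 (within the scatter). This first matched step in the series shows that the read-out does not separate the cyanomethyl and 2-(diethylcarbamoyl)ethyl forms, even though the entering group is considerably larger and brings a carbonyl and an amide nitrogen in place of the nitrile. No supporting measurement is available to explain this result.

On these data alone, whether a carboxylic acid or a dimethylamino group at the end of this chain, or a longer chain, would separate from compound 2 at 10000 nM remains open. Within the data shown here, the single step also leaves open how changes elsewhere on the shared core would read in this assay.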